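Swapping a pyridine for a fluorinated phenyl ring

The source may hold more compounds than are shown below. What is called first, only, known or untested is meant among the compounds shown, and "the series" means these compounds.

Measured so far:
compound 1 `O=C(NCCCNc1nc(Nc2cccnc2)ncc1C1CC1)C1CCC1`: > 1000 nM
compound 2 `Cc1nn(C)c2cc(Nc3ncc(C4CC4)c(NCCCNC(=O)C4CCC4)n3)ccc12`: 90 nM
compound 3 `O=C(NCCCNc1nc(Nc2cnn(C3CCOCC3)c2)ncc1C1CC1)C1CCC1`: 280 nM

Three compounds share one core and differ only in the aromatic group on the outer amino nitrogen. In an assay on RAW264.7 cells for inhibition of serine/threonine-protein kinase TBK1 (Mus musculus), read by ELISA, with stated times of 30 min and 6 h (a lower number here means a stronger inhibitor, a higher number a weaker inhibitor), compound 1 gives > 1000 nM, which is a limit of the assay and not a number (the limit of > 1000 nM in this assay, at which 1 of the 3 values shown sits). Compound 2 gives 90 nM and compound 3 gives 280 nM, so compound 1 is the one of the three for which no strength could be read.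

Compound 4 `O=C(NCCCNc1nc(Nc2cccc(F)c2)ncc1C1CC1)C1CCC1` carries 3-fluorophenyl in place of pyridin-3-yl on a nitrogen on an aromatic ring. Within the data shown here, no measured pair isolates this change, so the expectation rests on the three values alone. Compound 4 is expected to come in at 700 nM, within 200 nM to 3000 nM. The estimated step of an at least 1.4-fold lower number from compound 1 to compound 4 (0.15 log units; that floor lies within the scatter) is expected to be modest and toward a stronger inhibitor, with a real chance that only a limit is again reported.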

Compound 4, half-maximal inhibitory concentration: 1300 nM
For compound 4 the middle estimate is 1.9-fold (0.27 log units) below the measured one, and the stated range covers the measured number.
By their numbers in this assay, from the lowest: compound 2; then compound 3; then compound 4.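

No size can be given for the change from compound 1 to compound 4, because compound 1 carries only a limit of the assay and not a number: the limit of > 1000 nM in this assay, at which 1 of the 4 values shown sits.

From the compounds shown here alone, whether 3-fluorophenyl gives a stronger or a weaker inhibitor than pyridin-3-yl on the shared core stays open.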